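The compounds below may be only part of what the source reports. "The series", "measured", "known", "first", "only" and "open" are said of these compounds alone.

Compound 1, structure `N#Cc1ccc(N2CC[C@H](NCCC(=O)c3csc4ccccc34)C2)cc1`, gives > 100000 nM in an assay on HEK293 cells for displacement of a labelled ligand from 5-hydroxytryptamine receptor 7 (Homo sapiens), read by scintillation counting, with a stated time of 1 h; on this read-out higher numbers stand for weaker inhibition and lower numbers for stronger inhibition.
Compound 2, structure `O=C(CCN1CCN(c2ccc([N+](=O)[O-])cc2)CC1)c1csc2ccccc12`, gives > 100000 nM in this assay.
Compound 3, structure `O=[N+]([O-])c1ccc(N2CCCN(CCC(O)c3csc4ccccc34)CC2)c(C(F)(F)F)c1`, gives 8710 nM in this assay.

Compound 1 sits at a limit of this assay rather than at a measured number. Compound 2 also sits at that limit. Compound 3 is the only one of the three with a numeric value, and that value is itself weak. So the measured picture is one of weak or undetectable binding throughout: the limit of > 100000 nM in this assay, at which 2 of the 3 values shown sit.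

Compound 4, structure `O=C(CCN[C@H]1CCN(c2ccc([N+](=O)[O-])cc2)C1)c1csc2ccccc12`, has not been measured. It differs from compound 1 in one place: nitro in place of cyano on an aromatic carbon. Among the measured compounds shown here, no measured pair in this set shows what such an exchange does on its own, so the size and direction of the step are open. Compound 2 carries a nitro on its aryl ring and is still at the limit, while compound 3 carries a nitro and gives a weak number, which gives no ground to expect a large gain.

Compound 4 is therefore expected to remain weak, with an estimated value of 90000 nM (range 20000 nM to 300000 nM), and the expected step from compound 1 to compound 4 is an at least 1.1-fold lower number from compound 1 to compound 4 (0.04 log units; that floor lies within the scatter), likely no more than the scatter.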

Compound 4, inhibition constant: > 100000 nM
Compound 4: only a limit was reported; the forecaster's own chance of this, stated with the estimate: 60%; at least 1.1-fold (0.04 log units) between middle value and limit.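

Compound 1 and compound 4 both sit at a limit of this assay, so no step between them can be read: the limit of > 100000 nM in this assay, at which 3 of the 4 values shown sit.

The compounds shown leave open whether cyano or nitro on the shared core gives stronger binding, and by how much.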